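Ether side-chain variation on the shared core

The compounds below may be only part of what the source reports. "The series", "measured", "known", "first", "only" and "open" are said of these compounds alone.

Compound 1 `COc1cc2ncnc(-n3nc(-c4ccccn4)nc3N)c2cc1OCc1ccccc1` and compound 2 `COCCOc1cc2c(-n3nc(-c4ccccn4)nc3N)ncnc2cc1OC` share one core and differ only in the group on a saturated chain carbon bound to an oxygen on an aromatic ring. In an assay on MCF7 cells for inhibition of Serine-protein kinase ATM (Homo sapiens), read by immunofluorescence, with a stated time of 1 h (on this read-out higher numbers stand for weaker inhibition and lower numbers for stronger inhibition), compound 1 gives 8600 nM and compound 2 gives 1200 nM. Among the compounds with values here, the single measured step is a 7.2-fold lower number from compound 1 to compound 2 (0.86 log units; beyond the scatter). Within the data shown here, compound 2 therefore stands lowest of the two numbers, with compound 1 its only neighbour. Compound 3 `CCN(CC)C(=O)COc1cc2c(-n3nc(-c4ccccn4)nc3N)ncnc2cc1OC` carries the change (diethylcarbamoyl in place of methoxymethyl on a saturated chain carbon bound to an oxygen on an aromatic ring). The measured step bears on this only in that the same place is varied; the groups exchanged there are different, so it gives no direction. A step of no more than modest size in this assay is expected, in either direction, and a result within the scatter is possible. Compound 3 is expected to give 1500 nM, within a range from 400 nM to 5000 nM. This corresponds to an expected step of a 1.3-fold higher number from compound 2 to compound 3 (0.10 log units; within the scatter).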

Compound 3, half-maximal inhibitory concentration: 5300 nM
Compound 3: middle estimate off by 3.5-fold (0.55 log units), on the low side, and the stated range ends below it.
By their numbers in this assay, from the lowest: compound 2; then compounds 3 and 1 (each within the scatter of the next).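

In this assay, replacing the 2-methoxyethyl of compound 2 with the (diethylcarbamoyl)methyl gives a 4.4-fold higher number from compound 2 to compound 3 (0.65 log units; beyond the scatter) and shows that this position does not accept every non-aromatic chain equally. The comparison of the two larger groups gives a 1.6-fold lower number from compound 1 to compound 3 (0.21 log units; within the scatter) and does not separate phenyl from diethylcarbamoyl at this place, so compound 2 alone stands apart, as the strongest inhibitor of the three. No measurement at hand accounts for the separation of methoxymethyl from the other two groups.

On these data alone, it remains open whether the lower number of compound 2 is tied to the methoxy end or to the chain as such, which a hydroxyethyl or a longer methoxyalkyl chain would test. A morpholine-ended chain or a carboxylic acid at this place would show how far the series extends to amines and acids.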